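From 3,4,5-trimethoxyphenyl to 4-methoxyphenyl in compound 1

A few compounds are considered here, and "the series" means these few. Any claim that something is new, unique, unknown or untested is made for them only; others in the source may bear on it.

Among the compounds with values here, in a functional assay on COLO 205 cells (Homo sapiens) for inhibition, read by sulforhodamine B assay, with a stated time of 48 h, tested at 50 uM (on this read-out higher numbers stand for more inhibition of growth at the one concentration tested and lower numbers for less inhibition of growth), compound 1 `COc1cc(/C=C/C(=O)/C=C/c2cc(OC)c(OC)c(OC)c2)ccc1OCc1cn(CCOc2cc(=O)oc3ccccc23)nn1` gives 86%, the highest of the three numbers measured so far. Compound 3 `COc1cc(/C=C/C(=O)/C=C/c2ccccc2)ccc1OCc1cn(CCCOc2cc(=O)oc3ccccc23)nn1` gives 43% and compound 2 `COc1cc(/C=C/C(=O)/C=C/c2ccco2)ccc1OCc1cn(CCCCCOc2cc(=O)oc3ccccc23)nn1` gives 33%, both lower than compound 1 by more than the usual scatter. Compound 4 `COc1ccc(/C=C/C(=O)/C=C/c2ccc(OCc3cn(CCOc4cc(=O)oc5ccccc45)nn3)c(OC)c2)cc1` keeps the core of compound 1 and changes one group: 4-methoxyphenyl in place of 3,4,5-trimethoxyphenyl on a double-bonded chain carbon bound to a double-bonded chain carbon. It carries 4-methoxyphenyl in place of 3,4,5-trimethoxyphenyl on a double-bonded chain carbon bound to a double-bonded chain carbon. Within the data shown here, no two measured compounds differ in one place only, so this assay offers no direct measure of this change. Compound 3 at 43% and compound 2 at 33% also lack the 3,4,5-trimethoxyphenyl group, but both differ from compound 1 elsewhere too, so they serve only as a loose lower guide. The estimated step of a number 26 percentage points lower from compound 1 to compound 4 (beyond the scatter) is a fall beyond the scatter, smaller than those gaps. For compound 4 the expected value is 60%, with an estimated range of 36% to 82%.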

Compound 4, percent growth inhibition at one concentration: 68%
For compound 4 the middle estimate is 8 percentage points below the measured one; the range from low to high includes it.
By their numbers in this assay, from the lowest: compounds 2 and 3 (each within the scatter of the next); then compound 4; then compound 1.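

In this assay, within the data shown here, the step of a number 18 percentage points lower from compound 1 to compound 4 (beyond the scatter) gives the first direct reading of a change on a double-bonded chain carbon bound to a double-bonded chain carbon, which the earlier compounds, all differing in more than one place, could not give. It shows that this place matters to the read-out, yet that the full 3,4,5-trimethoxyphenyl group is not needed for substantial inhibition of growth, as compound 4 still gives 68% with 4-methoxyphenyl there. Nothing at hand accounts for the fall. The compounds shown leave open whether 3,4-dimethoxyphenyl, 4-hydroxyphenyl or 4-dimethylaminophenyl at this place would hold the number or lose more of it. They also leave open whether the step keeps its size when the rest of the molecule differs from the core of compound 1.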